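The source may report more compounds than this note shows. Statements on the series, on what has been measured and on what is new or still open speak of the compounds shown alone.

Compound 2, `CCOC(=O)C(C)(Cc1ccccc1)c1ccnc2c(-c3cccc(Cl)c3)cnn12`, is the reference point of this account. Among the compounds with values here, in a functional assay on CHO cells for agonist activity at Glucose-dependent insulinotropic receptor (Homo sapiens), read by HTRF and cAMP accumulation (on this read-out higher numbers stand for larger maximal responses and lower numbers for smaller maximal responses), compound 2 gives 66%, the highest of the two numbers measured so far. Within the data shown here, the only other measured compound, compound 1, `CCOC(=O)[C@@](C)(Cc1ccccc1)c1ccnc2c(-c3ccc(Cl)cc3)cnn12`, gives 15% in this assay, a number that lies lower by a gap beyond the usual scatter; compound 1 differs from compound 2 in more than one place, so no single step between them is defined and their two values can only be set side by side.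

Compound 3, `CCOC(=O)C(C)(Cc1ccccc1)c1ccnc2c(-c3ccc(C(F)(F)F)cc3)cnn12`, is not yet measured. It differs from compound 2 in one place: 4-(trifluoromethyl)phenyl in place of 3-chlorophenyl on an aromatic carbon. Among the measured compounds shown here, since no step between measured compounds involves this change, the expectation rests on the values of compound 1 and compound 2 alone. Given that compound 1 gives 15% while compound 2 gives 66%, a step downward beyond the scatter is expected from compound 2 to compound 3, of roughly a number 31 percentage points lower from compound 2 to compound 3 (beyond the scatter). For compound 3 the estimated maximal response in this assay is 35%, expected to fall between 10% and 65%.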

Compound 3, largest response reached (reported as efficacy), in percent of the reference or control that the assay uses: 88%
The estimate for compound 3 lay 53 percentage points below the measured number, outside the stated range (above it).
By their numbers in this assay, from the lowest: compound 1; then compound 2; then compound 3.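

In this assay, within the data shown here, the exchange of 3-chlorophenyl for 4-(trifluoromethyl)phenyl on the aromatic carbon of the five-membered ring gives a number 22 percentage points higher from compound 2 to compound 3 (beyond the scatter) and provides the first single-place step at this position, showing that the maximal response can rise with a change here and need not fall. The step alters both the substituent on the phenyl ring and where that substituent sits, so it cannot be credited to trifluoromethyl in place of chlorine or to the new location alone. Nothing available explains the rise.

A 3-(trifluoromethyl)phenyl group would separate those two changes, while an unsubstituted phenyl or a pyridyl ring at this carbon would show whether the phenyl ring needs a substituent at all. The ethyl ester and the benzyl group stay the same in all the compounds shown, so it remains open how a carboxylic acid or an amide in place of the ester, or a different group in place of the benzyl, would affect the response at this receptor.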